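The compounds below may be only part of what the source reports. "The series", "measured", "known", "first", "only" and "open" are said of these compounds alone.

Measured compounds:
- compound 1, `COc1ccc2nc(C)cc(OCC(=O)Nc3cc(C)cc(C)c3)c2c1`: 26000 nM
- compound 2, `Cc1cc(C)cc(NC(=O)COc2cc(C)nc3ccc(C)cc23)c1`: 83000 nM
- compound 3, `Cc1cc(C)cc(NC(=O)COc2cc(C)nc3ccc(C(F)(F)F)cc23)c1`: 10000 nM

All three share one core and differ only in the substituent on the aromatic carbon that carries methoxy in compound 1. In a physicochemical assay for solubility, in phosphate buffer, measured as kinetic solubility, with a stated time of 1 h, at pH 7.4 (a higher number here means a more soluble compound, a lower number a less soluble compound), compound 1 stands second highest of the three numbers; the nearest is compound 3 with a 2.6-fold lower number from compound 1 to compound 3 (0.41 log units; beyond the scatter), the furthest compound 2 with a 3.2-fold higher number from compound 1 to compound 2 (0.50 log units; beyond the scatter). Between the other two, an 8.3-fold lower number from compound 2 to compound 3 (0.92 log units; beyond the scatter).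

The unmeasured compound 4, `Cc1cc(C)cc(NC(=O)COc2cc(C)nc3ccc(OCc4ccccc4)cc23)c1`, differs from compound 1 by phenyl in place of hydrogen on a saturated chain carbon bound to an oxygen on an aromatic ring. Going by the values given here, none of the measured steps makes this change: they swap the group at that aromatic carbon, whereas here the methoxy is kept and extended. The measured steps bear on it only as a gauge of how sensitive this assay is to edits at that position: each is modest and beyond the scatter, in both directions. The change to compound 4 adds more heavy atoms than any measured step, so a step beyond the scatter is expected, and a lower number is expected rather than a higher one. The expected step is a 4.3-fold lower number from compound 1 to compound 4 (0.64 log units; beyond the scatter). For compound 4 the estimate in this assay is 6000 nM, with a range from 2000 nM to 18000 nM.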

Compound 4, solubility: < 1000 nM
Compound 4: only a limit was reported; the forecaster's own chance of this, stated with the estimate: 5%; at least 6.0-fold (0.77 log units) between middle value and limit.
By their numbers in this assay, from the lowest: compound 3; then compound 1; then compound 2. At a limit, below all of these: compound 4.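

In this assay the reading for compound 4 is a limit and not a number: the limit of < 1000 nM in this assay, at which 1 of the 4 values shown sits. Phenyl in place of hydrogen on a saturated chain carbon bound to an oxygen on an aromatic ring gives an at least 26-fold lower number from compound 1 to compound 4 (1.41 log units; beyond the scatter), a large step, whereas the swaps among the earlier compounds were all modest, so extending the methoxy moves this read-out further than any exchange of methoxy, methyl and trifluoromethyl did. Against the other two groups at that aromatic carbon the steps are an at least 10-fold lower number from compound 3 to compound 4 (1.00 log units; beyond the scatter) and an at least 83-fold lower number from compound 2 to compound 4 (1.91 log units; beyond the scatter), which puts benzyloxy, not trifluoromethyl, at the low end of the groups shown at this position, with the true size of all three steps still bounded only on one side.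

Open, going by these compounds, is whether the step needs the phenyl ring itself or would also come with a plain longer chain on that oxygen, such as propoxy or butoxy. Also open, on these data alone, is whether an amine or a carboxylic acid at the end of such a chain, or on the phenyl of the benzyloxy, would bring the number back up.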